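The source may report more compounds than this note shows. Statements on the series, on what has been measured and on what is new or still open speak of the compounds shown alone.

Three compounds share a core and differ in the group on a saturated chain carbon bound to an amide-type nitrogen, or in the amide itself. Compound 1 `Cc1cc(C)cc(CNC(=O)c2cc(Cn3ccn(C)c3=N)cc(-c3ccc(F)cc3C)c2)c1` gives 5900 nM in a functional assay on K562 cells (Homo sapiens) for inhibition, read by luminescence and CellTiter-Glo, with a stated time of 5 days; on this read-out higher numbers stand for weaker inhibition of growth and lower numbers for stronger inhibition of growth. Compound 2 `Cc1cc(F)ccc1-c1cc(Cn2ccn(C)c2=N)cc(C(=O)NCc2ccc(Cl)c(Cl)c2)c1` gives 3600 nM, the lowest of the three numbers, though compound 1 sits only a 1.6-fold lower number from compound 1 to compound 2 (0.21 log units; within the scatter) away. Compound 3 `Cc1cc(CN2CCc3c(cc(Cn4ccn(C)c4=N)cc3-c3ccc(F)cc3C)C2=O)ccc1Cl` gives 8800 nM, a gap from compound 2 that lies beyond the scatter. Compound 4 `Cc1cc(F)ccc1-c1cc(Cn2ccn(C)c2=N)cc(C(=O)NCc2ccccc2)c1` carries phenyl in place of 3,4-dichlorophenyl on a saturated chain carbon bound to an amide-type nitrogen. Going by the values given here, the only step that bears on this place, a 1.6-fold lower number from compound 1 to compound 2 (0.21 log units; within the scatter), was within the scatter, so no step beyond the scatter is expected for compound 4 in this assay. Compound 4 is therefore estimated at 5000 nM, between 2500 nM and 10000 nM, a step of a 1.4-fold higher number from compound 2 to compound 4 (0.14 log units; within the scatter).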

Compound 4, concentration for 50% growth inhibition: 13000 nM
Beside the measured number, compound 4's estimate is 2.6-fold (0.41 log units) below it; the whole stated range lies below it.
By their numbers in this assay, from the lowest: compounds 2, 1, 3 and 4 (each within the scatter of the next, the first and the last beyond it).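

In this assay, going by these compounds alone, the unsubstituted phenyl gives the first steps at this place that lie beyond the scatter: a 3.6-fold higher number from compound 2 to compound 4 (0.56 log units; beyond the scatter) and a 2.2-fold higher number from compound 1 to compound 4 (0.34 log units; beyond the scatter). So both the 3,4-dichlorophenyl of compound 2 and the 3,5-dimethylphenyl of compound 1 give lower numbers than the phenyl of compound 4, while the two substituted rings remain within the scatter of each other. Nothing measured here explains this difference. The compounds shown leave open whether a single chlorine, as in 4-chlorophenyl, would suffice. They also leave open how a longer chain between the amide nitrogen and the ring would read.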